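Hydroxy in place of bromo: outlook for compound 4

The source may hold more compounds than are shown below. What is called first, only, known or untested is meant among the compounds shown, and "the series" means these compounds.

Three members of the series have been tested in a functional assay on HCT-116 cells (Homo sapiens) for antiproliferative activity, read by MTT assay, with a stated time of 24 h; on this read-out lower numbers stand for stronger inhibition and higher numbers for weaker inhibition. Compound 1 `COc1ccc(/C=C/C(=O)c2ccc(OC)c3c2OC(C)(C)C=C3)c(F)c1` returns only a limit of this assay, > 10000 nM, not a number. Compound 2 `COc1ccc(C(=O)/C=C/c2ccc(Br)cc2)c2c1C=CC(C)(C)O2` likewise returns only a limit, > 10000 nM. For the measured compounds named here, compound 3 `COc1ccc(C(=O)/C=C/c2ccc(Cl)c(Cl)c2)c2c1C=CC(C)(C)O2` is the one member with a number, giving 9440 nM. Compound 2 thus stands at a limit, and one of the two other values shown is a limit too, so its place among them cannot be read off; the evidence here is the limit of > 10000 nM in this assay, at which 2 of the 3 values shown sit.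

The steps between the measured compounds give little to hold on to. The step that the two limits leave unreadable from compound 1 to compound 2 is not readable. The steps of an at least 1.0-fold lower number from compound 1 to compound 3 (0.02 log units; that floor lies within the scatter) and an at least 1.0-fold lower number from compound 2 to compound 3 (0.02 log units; that floor lies within the scatter) each carry only a floor that lies within the scatter.

Compound 4 `COc1ccc(C(=O)/C=C/c2ccc(O)cc2)c2c1C=CC(C)(C)O2` differs from compound 2 in one place: hydroxy in place of bromo on an aromatic carbon. Going by the values given here, none of the measured steps involves a hydroxy group, and the only step that starts from compound 2 has a floor within the scatter. The step of a number no higher from compound 2 to compound 4 (the limit leaves the size open) is therefore expected to stay within the scatter, in either direction. For compound 4 the expectation in this assay is 10000 nM, in a range from 3000 nM to 30000 nM, with a fair chance that only a limit is returned again.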

Compound 4, half-maximal inhibitory concentration: > 10000 nM
Compound 4: a limit, no number (the forecaster's own chance of this, stated with the estimate: 55%); the middle value sits exactly at the limit.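

Exchanging bromo for hydroxy on this aromatic carbon, para to a large group, adds a hydrogen-bond donor and a hydrogen-bond acceptor, yet in this assay compound 4 gives only a limit, > 10000 nM. The steps between compounds that sit at this limit cannot be read, and an at least 1.0-fold higher number from compound 3 to compound 4 (0.02 log units; that floor lies within the scatter) carries only a floor that lies within the scatter. The position now holds a hydroxy group as well as a bromo without either giving a number, and the picture in this assay remains one of limits: the limit of > 10000 nM in this assay, at which 3 of the 4 values shown sit.

On these data alone, whether an amine or a carboxylic acid on this aromatic carbon would return a number in this assay stays open, as does the size of any difference between bromo and hydroxy. For the compounds shown here, compound 3, at 9440 nM, remains the only member with a number, and no trend across the aryl groups can be drawn from it.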